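The source may report more compounds than this note shows. Statements on the series, on what has been measured and on what is new or still open speak of the compounds shown alone.

Working notes on the series, read in an ADME assay on LLC-MK2 cells (Macaca mulatta) for cytotoxicity, read by spectrophotometry and crystal violet staining, with a stated time of 4 days; on this read-out lower numbers stand for higher toxicity in this test and higher numbers for lower toxicity in this test. Compound 2 (`CC(C)n1ncc2c(C(=O)Nc3ccc(F)cc3)cc(-c3ccsc3)nc21`) gives > 200000 nM, which is a limit of the assay and not a number. Compound 3 (`CC(C)n1ncc2c(C(=O)Nc3ccc(F)cc3)cc(C3CC3)nc21`) carries cyclopropyl in place of thiophen-3-yl on an aromatic carbon. No measured step sizes this change. Among the compounds with values here, the only guide is compound 1 (`CC(C)n1ncc2c(C(=O)Nc3ccccn3)cc(C3CC3)nc21`), which also carries cyclopropyl and gives 25000 nM in this assay. A clear move toward lower numbers is therefore expected, with the expected step being an at least 2.8-fold lower number from compound 2 to compound 3 (0.45 log units; beyond the scatter). The estimated value for compound 3 is 70000 nM, with an expected range of 20000 nM to 200000 nM.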

Compound 3, half-maximal cytotoxic concentration: 12500 nM
Compound 3: middle estimate off by 5.6-fold (0.75 log units), on the high side; measured number below the stated range.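

In this assay, within the data shown here, cyclopropyl in place of thiophen-3-yl on the aromatic carbon next to the ring nitrogen gives an at least 16-fold lower number from compound 2 to compound 3 (1.20 log units; beyond the scatter), the first sized reading of this change. That size is only a bound because compound 2 stands at a limit of the assay: the limit of > 200000 nM in this assay, at which 1 of the 3 values shown sits. With cyclopropyl held, 4-fluorophenyl in place of pyridin-2-yl on the amide-type nitrogen gives a 2.0-fold lower number from compound 1 to compound 3 (0.30 log units; within the scatter), so these two groups are not told apart here.

Open, from the compounds shown here alone, is how an amine or a longer alkyl chain on this aromatic carbon would read. Also open, going by these compounds, is whether thiophen-3-yl reads the same with pyridin-2-yl on the amide-type nitrogen.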